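The compounds below may be only part of what the source reports. "The series", "measured", "known", "first", "only" and "open" are said of these compounds alone.

Measured so far:
compound 1 `C=C1[C@@H](OC(C)=O)C[C@@H]2[C@](C)(CO[Si](C)(C)C(C)(C)C)[C@H](OC(C)=O)CC[C@@]2(C)[C@@H]1C[C@@H](Nc1cccc2ccccc12)C1=CCOC1=O`, 8930 nM
compound 2 `C=C1[C@@H](OC(C)=O)C[C@@H]2[C@](C)(CO[Si](C)(C)C(C)(C)C)[C@H](OC(C)=O)CC[C@@]2(C)[C@@H]1C[C@@H](Nc1cccc(OC)c1)C1=CCOC1=O`, 45200 nM

Both were tested in a functional assay on KB cells (Homo sapiens) for cytotoxicity, read by sulforhodamine B assay; on this read-out lower numbers stand for stronger inhibition and higher numbers for weaker inhibition. Among the compounds with values here, compound 2 gives the higher of the two numbers; the only step to it, a 5.1-fold higher number from compound 1 to compound 2 (0.70 log units; beyond the scatter), is modest but beyond the scatter. Compound 3 `C=C1[C@@H](OC(C)=O)C[C@@H]2[C@](C)(CO[Si](C)(C)C(C)(C)C)[C@H](OC(C)=O)CC[C@@]2(C)[C@@H]1C[C@@H](Nc1ccccc1C(=O)O)C1=CCOC1=O` differs from compound 2 in one place: 2-carboxyphenyl in place of 3-methoxyphenyl on an amine nitrogen. Within the data shown here, no measured step exchanges one phenyl substituent for another, so the one step at hand says little about this change. Compound 3 is therefore expected to sit close to compound 2, with a 1.1-fold higher number from compound 2 to compound 3 (0.04 log units; within the scatter), and its estimate is 50000 nM within the range 15000 nM to 200000 nM.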

Compound 3, half-maximal inhibitory concentration: 6050 nM
For compound 3 the middle estimate is 8.3-fold (0.92 log units) above the measured one, and the stated range ends above it.
By their numbers in this assay, from the lowest: compounds 3 and 1 (each within the scatter of the next); then compound 2.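

The step of a 7.5-fold lower number from compound 2 to compound 3 (0.87 log units; beyond the scatter) in this assay shows that a single-ring group on this amine nitrogen need not give the higher number. With a 1.5-fold lower number from compound 1 to compound 3 (0.17 log units; within the scatter), 2-carboxyphenyl stands level with naphthalen-1-yl, so ring count alone does not set the value across these three compounds. No measurement given here accounts for this result. Going by these compounds, what remains open is whether the change follows the carboxylic acid itself or its place on the ring. An unsubstituted phenyl, or a methyl ester or amide in place of the acid, would help separate these.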